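The compounds below may be only part of what the source reports. "The series", "measured", "known", "first", "only" and "open" are said of these compounds alone.

Compound 1 `CCNC(=O)c1ccc(NC2CCCCC2)c(N)c1` and compound 2 `CCNC(=O)c1ccc(NC2CCCCC2)c(NCc2ccccc2)c1` share one core; compound 3 `CCNS(=O)(=O)c1ccc(NC2CC2)c(N)c1` and compound 4 `CCNS(=O)(=O)c1ccc(NC2CC2)c(NCc2ccccc2)c1` share another, and the difference between the two cores is not broken down here. In a functional assay (IMR-32 cells, Homo sapiens) for inhibition, read by fluorescence, with stated times of 1 h and 13 h (a higher number here means a weaker inhibitor, a lower number a stronger inhibitor), compound 1 gives 88 nM, while compound 2 gives 21 nM; the change between them is benzyl in place of hydrogen on a nitrogen on an aromatic ring, and it made a step of a 4.2-fold lower number from compound 1 to compound 2 (0.62 log units; beyond the scatter). In this assay compound 3 gives 76 nM, within the scatter of compound 1. Compound 4 carries the same change on its own core, (benzyl in place of hydrogen on a nitrogen on an aromatic ring), the place being described in identical words. Compound 4 is expected to show a step of a 3.5-fold lower number from compound 3 to compound 4 (0.54 log units; beyond the scatter) because the same change gave a 4.2-fold lower number from compound 1 to compound 2 (0.62 log units; beyond the scatter), with some allowance for the different core. Compound 4 is therefore estimated at 22 nM in this assay, most likely between 9 nM and 50 nM.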

Compound 4, half-maximal inhibitory concentration: 61 nM
Beside the measured number, compound 4's estimate is 2.8-fold (0.44 log units) below it, and the stated range ends below it.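

In this assay the benzyl change on the second core gives a 1.2-fold lower number from compound 3 to compound 4 (0.10 log units; within the scatter) and so does not repeat the clear step seen on the first core. The size of the step depends on the core in this pair of pairs: the same change on two cores in this assay, a 4.2-fold lower number (0.62 log units; beyond the scatter) from compound 1 to compound 2 and a 1.2-fold lower number (0.10 log units; within the scatter) from compound 3 to compound 4, 3.4-fold (0.53 log units) apart, beyond the scatter of two such steps. This shows that the step from the core of compound 1 cannot be carried over as a fixed amount to the core of compound 3, but it does not show which difference between the cores matters, and two pairs establish no rule for the series.

Open, on these data alone, is whether methyl or phenylethyl on the same nitrogen would follow the same core dependence. Also open is how benzyl behaves on a core that differs from either shown in one place only.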